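A few compounds are considered here, and "the series" means these few. Any claim that something is new, unique, unknown or untested is made for them only; others in the source may bear on it.

Measured compounds and values in a functional assay on PC-3 cells (Homo sapiens) for inhibition, read by sulforhodamine B assay, with a stated time of 48 h; on this read-out lower numbers stand for stronger inhibition and higher numbers for weaker inhibition:
compound 1 `CC[C@H](C)C(=O)O[C@H]1C[C@@H](C)C=C2C=C[C@H](C)[C@H](CC[C@@H](O)C[C@@H](CC(=O)NO)OC(=O)C(C)(C)C)[C@H]21` — 7200 nM
compound 2 `CC[C@H](C)C(=O)O[C@H]1C[C@@H](C)C=C2C=C[C@H](C)[C@H](CC[C@@H](O)C[C@@H](CC(=O)NO)OC(=O)c3ccccc3)[C@H]21` — 3300 nM
compound 3 `CC[C@H](C)C(=O)O[C@H]1C[C@@H](C)C=C2C=C[C@H](C)[C@H](CC[C@@H](O)C[C@@H](CC(=O)NO)OC(=O)c3ccc([N+](=O)[O-])cc3)[C@H]21` — 8200 nM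

Among the three, compound 3 has the highest number in this assay; its nearest neighbour is compound 1, from which it sits within the scatter, while compound 2 lies further off, with a 2.5-fold higher number from compound 2 to compound 3 (0.40 log units; beyond the scatter) marking that gap. The unmeasured compound 4 `CC[C@H](C)C(=O)O[C@H]1C[C@@H](C)C=C2C=C[C@H](C)[C@H](CC[C@@H](O)C[C@@H](CC(=O)NO)OC(=O)CCc3ccccc3)[C@H]21` differs from compound 3 at one place:

phenethyl in place of 4-nitrophenyl on a carbonyl carbon

Among the compounds with values here, two measured steps bear on this change. The step of a 2.5-fold higher number from compound 2 to compound 3 (0.40 log units; beyond the scatter) shows what adding the nitro did on the same carbonyl carbon, and the step of a 2.2-fold lower number from compound 1 to compound 2 (0.34 log units; beyond the scatter) shows a phenyl on that carbonyl carbon giving a lower number than a tert-butyl. Compound 4 removes the nitro and carries a phenyl on a two-carbon chain, so a modest drop in number is expected, roughly a 1.8-fold lower number from compound 3 to compound 4 (0.26 log units; within the scatter), landing between compound 2 and compound 1. Compound 4 is therefore estimated at 4500 nM in this assay, with a range from 2000 nM to 10000 nM.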

Compound 4, half-maximal inhibitory concentration: 6200 nM
Compound 4: middle estimate off by 1.4-fold (0.14 log units), on the low side; the range from low to high includes it.
By their numbers in this assay, from the lowest: compounds 2, 4, 1 and 3 (each within the scatter of the next, the first and the last beyond it).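

In this assay, swapping 4-nitrophenyl for phenethyl on the carbonyl carbon gives a 1.3-fold lower number from compound 3 to compound 4 (0.12 log units; within the scatter), while the other two swaps give a 1.9-fold higher number from compound 2 to compound 4 (0.27 log units; within the scatter) and a 1.2-fold lower number from compound 1 to compound 4 (0.06 log units; within the scatter). Compound 4 therefore lies within the scatter of all three earlier compounds, whereas compound 2 stands beyond the scatter of both compound 1 and compound 3, so phenethyl cannot be placed on either side of that earlier gap. No measurement shown here accounts for this result.

The compounds shown leave open whether a longer chain carrying the phenyl, or an amine or a carboxylic acid at this place, would separate from these four values beyond the scatter. They also leave open whether phenethyl would read the same way in any other cell line.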